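Ester Tail Change: Methyl Out, Hydroxy In

A few compounds are considered here, and "the series" means these few. Any claim that something is new, unique, unknown or untested is made for them only; others in the source may bear on it.

Three esters sharing one core have been measured in a functional assay on RAW264.7 cells (Mus musculus) for inhibition, read by ELISA, with a stated time of 24 h; a higher number here means that more compound is needed for the effect, a lower number that less compound is needed. Compound 1 `CC/C=C\C[C@H]1C(=O)C=C[C@H]1CC(=O)OCC` gives 20000 nM in this assay. Compound 2 `CC/C=C\C[C@H]1C(=O)C=C[C@H]1CC(=O)OCCC` gives 23000 nM. Compound 3 `CC/C=C\C[C@H]1C(=O)C=C[C@H]1CC(=O)OCc1ccccc1` gives 20000 nM. Compound 2 sits among these three numbers with no separation of note: the step of a 1.2-fold higher number from compound 1 to compound 2 (0.06 log units; within the scatter) and the step of a 1.2-fold lower number from compound 2 to compound 3 (0.06 log units; within the scatter) both fall within the scatter, as does the step of no change at the digits printed from compound 1 to compound 3 (within the scatter) between the other two.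

The next compound, compound 4 `CC/C=C\C[C@H]1C(=O)C=C[C@H]1CC(=O)OCCO`, differs from compound 2 in one place: hydroxy in place of methyl on a saturated chain carbon, two bonds along the chain from an oxygen next to a carbonyl group

The measured steps that touch this region all concern carbon groups on the ester tail. The step of a 1.2-fold higher number from compound 1 to compound 2 (0.06 log units; within the scatter) adds a methyl at the very position now in question, and the steps of no change at the digits printed from compound 1 to compound 3 (within the scatter) and a 1.2-fold lower number from compound 2 to compound 3 (0.06 log units; within the scatter) exchange carbon groups one bond closer to the oxygen; each stayed within the scatter. Among the measured compounds shown here, none of them introduces a hydroxy, so there is no direct precedent for this particular change. Given that every tail variation so far left this assay unmoved, the expectation is a step of a 1.0-fold lower number from compound 2 to compound 4 (0.02 log units; within the scatter) of no size beyond the scatter. Compound 4 is therefore estimated at 22000 nM, with a range from 9000 nM to 55000 nM.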

Compound 4, half-maximal effective concentration: 24000 nM
Beside the measured number, compound 4's estimate is 1.1-fold (0.04 log units) below it; measured number inside the range.
By their numbers in this assay, from the lowest: compounds 1, 3, 2 and 4 (each within the scatter of the next).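

Hydroxy differs from the carbon groups seen so far at this position, a saturated chain carbon two bonds along the chain from an oxygen next to a carbonyl group: it brings a hydrogen-bond donor and a hydrogen-bond acceptor where methyl has neither, yet this assay shows a 1.0-fold higher number from compound 2 to compound 4 (0.02 log units; within the scatter) and so no separation. The picture holds against the other two esters, with a 1.2-fold higher number from compound 3 to compound 4 (0.08 log units; within the scatter) and a 1.2-fold higher number from compound 1 to compound 4 (0.08 log units; within the scatter) both printed as within the scatter, so among these four compounds the tail has tolerated carbon groups and hydroxy alike, and compound 4 does not stand apart from the rest. No separate measurement is available to explain this flat result.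

With all four numbers within the scatter of each other, the compounds shown leave open whether any change on this tail can move the number in this assay at all. An amine or a carboxylic acid at this position, or a longer chain ending in hydroxy, would test how far that tolerance extends.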